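The source may hold more compounds than are shown below. What is called first, only, known or untested is meant among the compounds shown, and "the series" means these compounds.

Two measured compounds share a core and differ in the group attached to it. Compound 1 `CCCCCCCCc1cn(Cc2cc(=O)oc3cc(O)ccc23)nn1` carries an eight-carbon chain there; in a functional assay on CFPAC-1 cells (Homo sapiens) for inhibition, read by MTT assay, with a stated time of 72 h (a higher number here means a weaker inhibitor, a lower number a stronger inhibitor), compound 1 gives 62700 nM. Compound 2 `O=c1cc(Cn2cc(-n3ccc4cc(I)ccc43)nn2)c2ccc(O)cc2o1` carries an aromatic group instead, and in this assay compound 2 gives 29900 nM. Compound 2 holds the lowest of the two numbers seen so far; its nearest neighbour, compound 1, sits at a higher number, and that gap is beyond the usual scatter. Compound 3 `Cc1ccc2c(Cn3cc(-n4ccc5cc(I)ccc54)nn3)cc(=O)oc2c1` keeps the aromatic group of compound 2 and differs from it only by methyl in place of hydroxy on an aromatic carbon. Among the measured compounds shown here, no measured pair differs in this one place, so the step has no anchor. The expected step in this assay is modest, if anything toward a higher number: a 1.3-fold higher number from compound 2 to compound 3 (0.10 log units; within the scatter). Compound 3 is expected to give 38000 nM, with a range from 13000 nM to 95000 nM.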

Compound 3, half-maximal inhibitory concentration: 41700 nM
For compound 3 the middle estimate is 1.1-fold (0.04 log units) below the measured one, within the range that was stated.
By their numbers in this assay, from the lowest: compounds 2, 3 and 1 (each within the scatter of the next, the first and the last beyond it).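

In this assay, among the compounds shown here, methyl in place of hydroxy on an aromatic carbon gives a 1.4-fold higher number from compound 2 to compound 3 (0.14 log units; within the scatter), the first step that can be read at this position. Hydroxy, with its hydrogen-bond donor and acceptor, can therefore give way to methyl, which has neither, without a difference beyond the scatter; on this pair, that hydroxy is not shown to be needed for the read-out in these cells. Nothing at hand bears on why compound 2 and compound 3 read alike.

From the compounds shown here alone, this position rests on a single pair with the aromatic group held constant, so it remains open whether the exchange would read the same with the eight-carbon chain of compound 1. Also open, going by these compounds, is how other groups on this aromatic carbon, such as an amine, a methoxy or a carboxylic acid, would read.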